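This account rests on a few compounds, and the source may have more. Where it says the series, first, only, none or still open, it means among the compounds named here.

Two members of this series have been run in an in vitro ADME assay on microsomes from liver (Homo sapiens) for pharmacokinetics, read by LC-MS, with a stated time of 10 min, tested at 1 uM; on this read-out lower numbers stand for slow clearance and higher numbers for fast clearance. Compound 1 `CN1C[C@H](C(=O)Nc2ccc(C#N)cc2)[C@@H](c2ccc(/C=C/C(=O)Nc3ccccc3N)cc2)C1` gives 1 mL/min/kg, and compound 2 `COc1cccc(NC(=O)[C@H]2CN(C)C[C@@H]2c2ccc(/C=C/C(=O)Nc3ccccc3N)cc2)c1` gives 14 mL/min/kg. Among the measured compounds shown here, the single change between them, 3-methoxyphenyl in place of 4-cyanophenyl on an amide-type nitrogen, produced a 14-fold higher number from compound 1 to compound 2 (1.15 log units; beyond the scatter). For the measured compounds named here, compound 2 thus stands at the higher of the two numbers measured so far, with compound 1 as its only neighbour.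

Compound 3 `Cc1cc(NC(=O)[C@H]2CN(C)C[C@@H]2c2ccc(/C=C/C(=O)Nc3ccccc3N)cc2)ccc1F` is the next step. It differs from compound 2 in one place: 4-fluoro-3-methylphenyl in place of 3-methoxyphenyl on an amide-type nitrogen. Going by the values given here, the only measured step that bears on this change is a 14-fold higher number from compound 1 to compound 2 (1.15 log units; beyond the scatter), which shows that exchanging the group on this amide-type nitrogen can move this assay a long way. That step, however, involved a different pair of groups, so it gives no direct guide to the direction here. For compound 3 the expectation in this assay is a 1.4-fold lower number from compound 2 to compound 3 (0.15 log units; within the scatter), a step not beyond the scatter, though a larger shift in either direction cannot be excluded. Compound 3 is therefore estimated to give 10 mL/min/kg, within a range from 3 mL/min/kg to 30 mL/min/kg.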

Compound 3, clearance: 15 mL/min/kg
Estimate against measurement, compound 3: 1.5-fold (0.18 log units) below; the measured number falls inside the stated range.
By their numbers in this assay, from the lowest: compound 1; then compounds 2 and 3 (each within the scatter of the next).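

In this assay, the exchange on the amide-type nitrogen gives a 1.1-fold higher number from compound 2 to compound 3 (0.03 log units; within the scatter), so this position, which had so far shown only a large move, also tolerates a change of group with no shift beyond the scatter. The two groups match in heavy atoms and in their single aromatic ring, while the oxygen and its hydrogen-bond acceptor of 3-methoxyphenyl give way to the fluorine of 4-fluoro-3-methylphenyl, which counts no acceptor, and this exchange leaves the read-out within the scatter. Compound 1 still stands apart, with a 15-fold higher number from compound 1 to compound 3 (1.18 log units; beyond the scatter), so the large gap is not tied to 3-methoxyphenyl alone but appears against both of the other groups, and no measurement shown gives a reason for it.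

As far as these compounds go, it remains open whether the low number of compound 1 goes with the nitrile itself, and how an unsubstituted phenyl, a 3-cyanophenyl or a pyridyl on this nitrogen would read. From the compounds shown here alone, the rest of the molecule is the same in all three compounds, so it is also open whether these steps would hold if the N-methyl group gave way to an N-ethyl group.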